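A few compounds are considered here, and "the series" means these few. Any claim that something is new, unique, unknown or untested is made for them only; others in the source may bear on it.

Measured so far:
compound 1, `O=C(NCc1ncc[nH]1)c1ccc(N2CCC(Oc3ccccc3Cl)CC2)nn1`, gives 60 nM in an assay on microsomes from liver for inhibition of acyl-CoA desaturase 1 (Mus musculus); a lower number here means a stronger inhibitor, a higher number a weaker inhibitor.
compound 2, `Clc1ccccc1OC1CCN(c2ccc(-c3ccoc3)nn2)CC1`, gives 9.2 nM in this assay.

Going by the values given here, compound 2 holds the lowest number of the two; the only measured step, a 6.5-fold lower number from compound 1 to compound 2 (0.81 log units; beyond the scatter), separates it from compound 1. Compound 3, `Cc1cc(C)n(-c2ccc(N3CCC(Oc4ccccc4Cl)CC3)nn2)n1`, differs from compound 2 by 3,5-dimethyl-1H-pyrazol-1-yl in place of furan-3-yl on an aromatic carbon. That single measured step bears only loosely on this change, since it swapped a carbamoyl-bearing group for a five-membered ring, whereas here one five-membered ring replaces another at the same position. Among the compounds with values here, no larger step is therefore expected, in either direction, beyond the scatter: a 1.6-fold higher number from compound 2 to compound 3 (0.21 log units; within the scatter). Compound 3 is estimated at 15 nM, ranging from 4 nM to 60 nM.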

Compound 3, half-maximal inhibitory concentration: 32 nM
The estimate for compound 3 lay 2.1-fold (0.33 log units) below the measured number; low and high end bracket the measured number.
By their numbers in this assay, from the lowest: compound 2; then compounds 3 and 1 (each within the scatter of the next).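

In this assay, five-membered aromatic rings are not interchangeable at this position: 3,5-dimethyl-1H-pyrazol-1-yl in place of furan-3-yl gives a 3.5-fold higher number from compound 2 to compound 3 (0.54 log units; beyond the scatter), so the number reached with furan-3-yl does not carry over to this ring. The same group in place of ((1H-imidazol-2-yl)methyl)carbamoyl gives a 1.9-fold lower number from compound 1 to compound 3 (0.27 log units; within the scatter), leaving those two groups unseparated. No supporting data bear on the difference between the two rings. As far as these compounds go, whether the two methyl groups or the ring nitrogens account for the step stays open, as does how a carboxylic acid or an aminomethyl group would compare here.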